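Piperidine Replaces Hydroxyl on the Chain

A few compounds are considered here, and "the series" means these few. Any claim that something is new, unique, unknown or untested is made for them only; others in the source may bear on it.

Measured so far:
compound 1 `CCCCNc1nc(N)nc(C)c1CCCN1CCN(C)CC1` — 179 nM
compound 2 `CCCCNc1nc(N)nc(C)c1CCCCO` — 1310 nM

For the measured compounds named here, compound 2 stands highest of the two numbers in an assay on HEK293 cells for agonist activity at Toll-like receptor 8 (Homo sapiens), read by spectrophotometry; on this read-out lower numbers stand for an effect already at smaller amounts and higher numbers for an effect only at larger amounts of compound; its nearest neighbour is compound 1, and the one measured step, a 7.3-fold higher number from compound 1 to compound 2 (0.86 log units; beyond the scatter), was modest. Compound 3 `CCCCNc1nc(N)nc(C)c1CCCN1CCCCC1` is not yet measured. It differs from compound 2 by piperidin-1-yl in place of hydroxymethyl on a saturated chain carbon, three bonds along the chain from an aromatic carbon. That step runs back toward the amine-bearing pattern of compound 1, so a lower number is expected, of size a 6.0-fold lower number from compound 2 to compound 3 (0.77 log units; beyond the scatter). The estimate for compound 3 is 220 nM, between 70 nM and 700 nM.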

Compound 3, half-maximal effective concentration: 133 nM
Estimate against measurement, compound 3: 1.7-fold (0.22 log units) above; the range from low to high includes it.
By their numbers in this assay, from the lowest: compounds 3 and 1 (each within the scatter of the next); then compound 2.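

In this assay a second ring amine at this position behaves like the first: piperidin-1-yl in place of hydroxymethyl gives a 9.8-fold lower number from compound 2 to compound 3 (0.99 log units; beyond the scatter) and so repeats the gap seen with 4-methylpiperazin-1-yl. Between the two ring amines, a 1.3-fold lower number from compound 1 to compound 3 (0.13 log units; within the scatter) lies within the scatter, so the second ring nitrogen and its methyl make no measurable difference here. Nothing available explains why either ring amine differs from the hydroxyl chain end.

Going by these compounds, whether an open-chain dimethylamino group or a morpholine ring would give a similar number remains open. So does the effect of a shorter or longer chain carrying the piperidine.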